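Losing the aromatic acyl group from compound 2

The source may report more compounds than this note shows. Statements on the series, on what has been measured and on what is new or still open speak of the compounds shown alone.

Going by the values given here, in a functional assay on K562 cells (Homo sapiens) for cytotoxicity, read by MTT assay (a higher number here means a weaker inhibitor, a lower number a stronger inhibitor), compound 2 `COc1cccc(C(=O)Oc2cc(/C=C/C(=O)c3ccc(OC)c4c3OC(C)(C)C=C4)ccc2OC)c1` gives 790 nM, the only actual number so far. Compound 1 `C=CCOc1cc(/C=C/C(=O)c2ccc(OC)c3c2OC(C)(C)C=C3)ccc1OC` is known only as a limit, > 10000 nM. Compound 3 `COc1ccc(/C=C/C(=O)c2ccc(OC)c3c2OC(C)(C)C=C3)cc1CS(C)(=O)=O` carries (methylsulfonyl)methyl in place of ((3-methoxyphenyl)carbonyl)oxy on an aromatic carbon, ortho to a methoxy group: (methylsulfonyl)methyl in place of ((3-methoxyphenyl)carbonyl)oxy on an aromatic carbon. Among the compounds with values here, one measured step bears on this, the large change an at least 12-fold lower number from compound 1 to compound 2 (1.10 log units; beyond the scatter), which came with the (3-methoxyphenyl)carbonyl group. With that group gone, a large step to a higher number is expected in this assay. The estimated step is a 5.7-fold higher number from compound 2 to compound 3 (0.76 log units; beyond the scatter). For compound 3 the expected value is 4500 nM, with an estimated range of 1500 nM to 15000 nM.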

Compound 3, half-maximal inhibitory concentration: 9240 nM
Compound 3: the middle estimate sits 2.1-fold (0.31 log units) below what was measured, within the range that was stated.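

In this assay, (methylsulfonyl)methyl in place of ((3-methoxyphenyl)carbonyl)oxy, on an aromatic carbon ortho to a methoxy group, brings a 12-fold higher number from compound 2 to compound 3 (1.07 log units; beyond the scatter). The low number of compound 2 is thus lost with a second, quite different group, not only with allyloxy. Compound 1 is known only as a limit. With (methylsulfonyl)methyl in place of allyloxy, the data give an at least 1.0-fold lower number from compound 1 to compound 3 (0.03 log units; that floor lies within the scatter), so this comparison offers only a floor, set by that limit: the limit of > 10000 nM in this assay, at which 1 of the 3 values shown sits.

From the compounds shown here alone, what stays open is whether the aromatic ring or the ester carbonyl of ((3-methoxyphenyl)carbonyl)oxy matters more. A benzyl ether and an acetate ester at this position would separate the two.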